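Trimming the Amide: From Anilide to Acetamido

The source may hold more compounds than are shown below. What is called first, only, known or untested is meant among the compounds shown, and "the series" means these compounds.

Compound 1, `Cc1cc(C(=O)O)nn1Cc1cc(Br)ccc1OCc1ccccc1`, gives 6.31 nM in an assay on CHO-K1 cells for displacement of a labelled ligand from prostaglandin E2 receptor EP1 subtype (Homo sapiens); a higher number here means a weaker inhibitor, a lower number a stronger inhibitor.
Compound 2, `Cc1cc(C(=O)Nc2c(F)cccc2F)nn1Cc1cc(Cl)ccc1OCc1ccccc1`, gives 10 nM in this assay.
Compound 3, `Cc1cc(C(=O)NN2CCOCC2)nn1Cc1cc(Cl)ccc1OCC(C)C`, gives 251 nM in this assay.

Compound 2 stands second highest of these three numbers. Its nearest neighbour is compound 1, whose number is lower by a margin within the usual scatter, so no order between the two can be claimed. Its furthest neighbour is compound 3, whose number is higher by a margin beyond the scatter.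

Compound 4, `CC(=O)Nc1cc(C)n(Cc2cc(Cl)ccc2OCc2ccccc2)n1`, differs from compound 2 in one place: acetamido in place of (2,6-difluorophenyl)carbamoyl on an aromatic carbon. For the measured compounds named here, no step between two measured compounds covers a change of this kind. Compound 3 carries both a different amide and a different ether relative to compound 2, so its value shows only the combined outcome, not the share of either change.

In this assay the step is expected to go to a higher number, beyond the scatter, as an 8.0-fold higher number from compound 2 to compound 4 (0.90 log units; beyond the scatter). Compound 4 is accordingly expected to give 80 nM, within a range from 20 nM to 400 nM.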

Compound 4, half-maximal inhibitory concentration: 316 nM
Compound 4: middle estimate off by 4.0-fold (0.60 log units), on the low side, and the stated range covers the measured number.
By their numbers in this assay, from the lowest: compounds 1 and 2 (each within the scatter of the next); then compounds 3 and 4 (each within the scatter of the next).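

In this assay, for the compounds shown here, putting acetamido in place of (2,6-difluorophenyl)carbamoyl gives a 32-fold higher number from compound 2 to compound 4 (1.50 log units; beyond the scatter) and is the first change at this position to be seen on its own. The number therefore depends strongly on this substituent, even though the two groups have the same hydrogen-bond donor and acceptor counts under this tally. The change removes the six-membered aromatic ring, shrinks the group from 11 heavy atoms to 4, and also places the amide nitrogen rather than the carbonyl on the aromatic carbon. Nothing available explains the rise in the number.

The compounds shown leave open which of these differences accounts for the step. A methylcarbamoyl group would keep the carbonyl on the aromatic carbon without the ring, while a benzamido group would keep the amide nitrogen there with a ring.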